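The source may report more compounds than this note shows. Statements on the series, on what has been measured and on what is new or still open speak of the compounds shown alone.

Series of three measured compounds sharing one core. Compound 1 `Cc1nc(S(C)(=O)=O)ccc1Oc1ncnc(OC2CCN(C(=O)OC(C)C)CC2)c1F` gives 142 nM in a functional assay on isolated protein for inhibition of Glucose-dependent insulinotropic receptor (Rattus norvegicus), read by HTRF and cAMP accumulation; on this read-out higher numbers stand for an effect only at larger amounts of compound and lower numbers for an effect already at smaller amounts. Compound 2 `Cc1nc(S(C)(=O)=O)ccc1Oc1ncnc(OC2CCN(C(=O)C(C)(C)F)CC2)c1F` gives 296 nM in this assay, and compound 3 `Cc1nc(S(C)(=O)=O)ccc1Oc1ncnc(OC2CCN(C(=O)c3noc(C(C)(C)F)n3)CC2)c1F` gives 103 nM in this assay. Compound 3 thus carries the lowest of the three numbers, although its gap to compound 1 lies within the scatter, so no order between compound 3 and compound 1 can be claimed; only the gap to compound 2 stands beyond it.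

Compound 4 `Cc1nc(S(C)(=O)=O)ccc1Oc1ncnc(OC2CCN(C(=O)c3ncc(Cl)cn3)CC2)c1F` has not been measured. It differs from compound 3 in that (a group of 7 heavy atoms (4 carbon, 2 nitrogen, 1 chlorine; one six-membered aromatic ring with 2 hetero atoms) in place of a group of 9 heavy atoms (5 carbon, 2 nitrogen, 1 oxygen, 1 fluorine; one five-membered aromatic ring with 3 hetero atoms), on a carbonyl carbon). Going by the values given here, the steps that bear on this are a 1.4-fold lower number from compound 1 to compound 3 (0.14 log units; within the scatter) and a 2.9-fold lower number from compound 2 to compound 3 (0.46 log units; beyond the scatter), both of which bring in the five-membered aromatic ring from a group without a ring; neither exchanges one ring for another, so they inform only loosely. Both were modest or within the scatter. For compound 4 no step beyond the scatter is expected in this assay, and the expected step from compound 3 is a 1.2-fold higher number from compound 3 to compound 4 (0.07 log units; within the scatter). Compound 4 is estimated at 120 nM, with a range from 50 nM to 300 nM.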

Compound 4, half-maximal effective concentration: 30.9 nM
Compound 4: the middle estimate sits 3.9-fold (0.59 log units) above what was measured; measured number outside the range, below it.
By their numbers in this assay, from the lowest: compound 4; then compounds 3 and 1 (each within the scatter of the next); then compound 2.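

At the carbonyl carbon bound to the amide-type nitrogen in a ring, 5-chloropyrimidin-2-yl separates compound 4 from every other member of the series in this assay: a 3.3-fold lower number from compound 3 to compound 4 (0.52 log units; beyond the scatter), a 4.6-fold lower number from compound 1 to compound 4 (0.66 log units; beyond the scatter) and a 9.6-fold lower number from compound 2 to compound 4 (0.98 log units; beyond the scatter). Going by these compounds alone, the step from the five-membered aromatic ring is the first exchange of one ring for another at this place, and it shows that carrying an aromatic ring here does not by itself fix the number, since the ring group of compound 3 stands within the scatter of the isopropoxy group of compound 1. Nothing at hand accounts for the lower number of compound 4.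

As far as these compounds go, the step changes ring size, hetero atoms and the chlorine together, so the share of each remains open. Pyrimidin-2-yl without chlorine, or with bromine or a nitrile in its place, would separate these contributions.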